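Cyclopentyl for benzyloxyethyl on the shared core: cytotoxicity notes

The source may report more compounds than this note shows. Statements on the series, on what has been measured and on what is new or still open speak of the compounds shown alone.

Compound 1 `OC[C@H]1O[C@@H](n2cnc3c(Nc4ccccc4)nc(NC4CCCC4)nc32)[C@H](O)[C@@H]1O` and compound 3 `OC[C@H]1O[C@@H](n2cnc3c(Nc4ccccc4)nc(NCCOCc4ccccc4)nc32)[C@H](O)[C@@H]1O` have both been run in an ADME assay on L6 cells (Rattus norvegicus) for cytotoxicity; a lower number here means a stronger inhibitor, a higher number a weaker inhibitor. Compound 3 gives 53800 nM, and compound 1 gives 36300 nM, so the change cyclopentyl in place of 2-(benzyloxy)ethyl on a nitrogen on an aromatic ring made a 1.5-fold lower number from compound 3 to compound 1 (0.17 log units; within the scatter). For compound 2 `OC[C@H]1O[C@@H](n2cnc3c(NCc4cccc(I)c4)nc(NCCOCc4ccccc4)nc32)[C@H](O)[C@@H]1O` the entry in this assay reads "not determined" (no result reported), so no result is reported for it. Compound 4 `OC[C@H]1O[C@@H](n2cnc3c(NCc4cccc(I)c4)nc(NC4CCCC4)nc32)[C@H](O)[C@@H]1O` is not yet measured. The change from compound 2 to compound 4 is cyclopentyl in place of 2-(benzyloxy)ethyl on a nitrogen on an aromatic ring, the same change as from compound 3 to compound 1, at the same place. The cores of compound 2 and compound 3 differ by 3-iodobenzyl in place of phenyl on a nitrogen on an aromatic ring. Since the cyclopentyl change on the compound 3 core stayed within the scatter, the step from compound 2 to compound 4 in this assay is expected to be small as well. Compound 4 is estimated to give about 35000 nM in this assay, between 12000 nM and 100000 nM.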

Compound 4, half-maximal inhibitory concentration: 51700 nM
Compound 4: the middle estimate sits 1.5-fold (0.17 log units) below what was measured; the measured number falls inside the stated range.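

In this assay the step of a 1.4-fold higher number from compound 1 to compound 4 (0.15 log units; within the scatter) stays within the scatter, so with cyclopentyl in place, 3-iodobenzyl and phenyl are not told apart. Among the compounds shown here, compound 2 has no reported number, so the step from it to compound 4 cannot be read, and the cyclopentyl change is seen only on the core of compound 3; its transfer to the 3-iodobenzyl core is neither confirmed nor refuted. No measurement shown bears on what lies behind these numbers.

Still open, on these data alone, is whether a carboxylic acid or an amine in place of 3-iodobenzyl, or a longer chain in place of cyclopentyl, would give a step beyond the scatter.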